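A Larger Chain-End Group on the Shared Core

The source may report more compounds than this note shows. Statements on the series, on what has been measured and on what is new or still open speak of the compounds shown alone.

Three measured compounds share one core and differ only in the group hanging from the end of a saturated chain. Compound 1 `C/N=C(\S)NCCCCCn1nc(-c2ccccc2)ccc1=O`, compound 2 `CN(C)/C(=N/CCCn1nc(-c2ccccc2)ccc1=O)NC#N` and compound 3 `C/N=C(\NC#N)NCCCCn1nc(-c2ccccc2)ccc1=O` were each tested in a functional assay on the whole organism with Rattus norvegicus as the target, at a dose of 100 mg/kg; on this read-out higher numbers stand for more inhibition at the one dose given (going by the name of the read-out) and lower numbers for less inhibition. Compound 1 gives 68.9%, compound 2 gives 72.2% and compound 3 gives 79%. Among these three numbers compound 1 stands lowest. The step of a number 3.3 percentage points higher from compound 1 to compound 2 (within the scatter) stays within the scatter, whereas the step of a number 10.1 percentage points higher from compound 1 to compound 3 (beyond the scatter) goes beyond it.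

Compound 4 `CN(C)/C(=N/CCCCCn1nc(-c2ccccc2)ccc1=O)NC#N` has not yet been measured. It differs from compound 1 by a group of 8 heavy atoms (4 carbon, 4 nitrogen; no ring) in place of a group of 5 heavy atoms (2 carbon, 2 nitrogen, 1 sulfur; no ring), on a saturated chain carbon, five bonds along the chain from an aromatic nitrogen. Both measured steps that bear on this change swapped a group holding one sulfur for a group holding four nitrogen atoms, and both moved the number upward, one within the scatter and one modestly beyond it. A small rise is therefore expected for compound 4, a number 5.1 percentage points higher from compound 1 to compound 4 (within the scatter). Compound 4 is estimated at 74%, with a range from 62% to 85%.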

Compound 4, a percentage reported as inhibition, in the whole organism at one dose (the size of the read-out at that dose, not a potency): 63.9%
The estimate for compound 4 lay 10.1 percentage points above the measured number; measured number inside the range.
By their numbers in this assay, from the lowest: compounds 4, 1, 2 and 3 (each within the scatter of the next, the first and the last beyond it).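

In this assay the exchange on a saturated chain carbon, five bonds along the chain from an aromatic nitrogen, gives a number 5 percentage points lower from compound 1 to compound 4 (within the scatter) and so brings no gain that can be told from the usual spread of repeats. Among the earlier exchanges of a sulfur-holding group for a group with four nitrogen atoms, only the one leading to compound 3 went beyond the scatter, and this new result adds no support for a general gain from such an exchange. Nothing available here explains the outcome at this position.

Still open, going by these compounds, is how an amine or a carboxylic acid at the end of this chain would compare. So is whether a longer chain carrying the group of compound 4 would give a number clearly apart from that of compound 1.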